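This account rests on a few compounds, and the source may have more. Where it says the series, first, only, none or still open, it means among the compounds named here.

Measured so far in a functional assay on A549 cells (Homo sapiens) for cytotoxicity, read by MTT assay, with a stated time of 48 h; on this read-out higher numbers stand for weaker inhibition and lower numbers for stronger inhibition:

compound 1 `CC(C)=CCC/C(C)=C/CC/C(C)=C/CC[C@@H]1[C@@]2(C)CC/C(=N\OCc3cn(-c4ccccc4C#N)nn3)C(C)(C)[C@@H]2CC[C@@]1(C)O` — 20000 nM
compound 2 `CC(C)=CCC/C(C)=C/CC/C(C)=C/CC[C@@H]1[C@@]2(C)CC/C(=N\OCc3cn(-c4cccc([N+](=O)[O-])c4)nn3)C(C)(C)[C@@H]2CC[C@@]1(C)O` — 14800 nM
compound 3 `CC(C)=CCC/C(C)=C/CC/C(C)=C/CC[C@@H]1[C@@]2(C)C/C(=C\c3ccc(OCc4cn(-c5ccccc5C#N)nn4)cc3)C(=O)C(C)(C)[C@@H]2CC[C@@]1(C)O` — 61700 nM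

Compound 1 and compound 2 share a core and differ in one place: 3-nitrophenyl in place of 2-cyanophenyl on an aromatic nitrogen. On this read-out that exchange gave a 1.4-fold lower number from compound 1 to compound 2 (0.13 log units; within the scatter), so the two values cannot be told apart. Compound 3 carries a different core; the difference between the two cores is not broken down here. Compound 3 stands as the highest number of the three, beyond the scatter from both compound 1 and compound 2.

Compound 4 `CC(C)=CCC/C(C)=C/CC/C(C)=C/CC[C@@H]1[C@@]2(C)C/C(=C\c3ccc(OCc4cn(-c5cccc([N+](=O)[O-])c5)nn4)cc3)C(=O)C(C)(C)[C@@H]2CC[C@@]1(C)O` has not been measured in this assay. It is related to compound 3 by the same change that relates compound 1 to compound 2: 3-nitrophenyl in place of 2-cyanophenyl on an aromatic nitrogen. The place of the change is described in the same words in both pairs. The expected step is a 1.2-fold lower number from compound 3 to compound 4 (0.09 log units; within the scatter), small like the earlier one, because a 1.4-fold lower number from compound 1 to compound 2 (0.13 log units; within the scatter) stayed within the scatter. Among the measured compounds shown here, for compound 4 the estimate is 50000 nM, with a range from 22000 nM to 120000 nM, resting on the single earlier step and on the value of compound 3.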

Compound 4, half-maximal inhibitory concentration: 126000 nM
Compound 4: the middle estimate sits 2.5-fold (0.40 log units) below what was measured; the measured number lies above the stated range.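

In this assay, 3-nitrophenyl in place of 2-cyanophenyl on an aromatic nitrogen gave a 2.0-fold higher number from compound 3 to compound 4 (0.31 log units; beyond the scatter), a modest step. The change therefore does not carry over with the same size from one core to the other in this pair of cores: the same change on two cores in this assay, a 1.4-fold lower number (0.13 log units; within the scatter) from compound 1 to compound 2 and a 2.0-fold higher number (0.31 log units; beyond the scatter) from compound 3 to compound 4, 2.8-fold (0.44 log units) apart, beyond the scatter of two such steps. The earlier step lies within the scatter, which makes this a difference in the size of the two steps and not a demonstrated reversal of direction, and it rests on a single pair for each core, with nothing to say how the change would behave on a third core.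

As far as these compounds go, only 2-cyanophenyl and 3-nitrophenyl are compared here, and it remains open whether the gap between the cores would persist with other groups on that nitrogen, such as a phenyl bearing an amine or a carboxylic acid, or a longer alkyl chain. Also open is which part of the difference between the two cores matters, as no pair shown separates it.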